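Bromo in Place of Cyano on a Fused Pyridine Antagonist

The source may report more compounds than this note shows. Statements on the series, on what has been measured and on what is new or still open speak of the compounds shown alone.

Of the compounds shown here, three have been measured in an in vitro functional assay on cells for antagonist activity at metabotropic glutamate receptor 1 (Rattus norvegicus), read by inositol phosphate accumulation; a higher number here means a weaker inhibitor, a lower number a stronger inhibitor. Compound 1 `CCc1nc(C#N)c(N2CCc3ccccc3CC2)nc1C` gives 6 nM. Compound 2 `CCCCCCNc1nc2c(cc1C#N)C(=O)CC(C)(C)C2` gives 2600 nM. Compound 3 `CC1(C)CC(=O)c2cc(C#N)c(N3CCN(c4ccc(F)cc4)CC3)nc2C1` gives 160 nM, which places it second highest of the three numbers: compound 2 stands higher by a gap beyond the scatter, and compound 1 stands lower by a still larger gap, also beyond the scatter. No two of the measured compounds differ in only one place, so none of these gaps can be read as the effect of a single change.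

Compound 4 `CC1(C)CC(=O)c2cc(Br)c(N3CCN(c4ccc(F)cc4)CC3)nc2C1` differs from compound 3 in one place: bromo in place of cyano on an aromatic carbon. Among the measured compounds shown here, no measured pair shows this exchange, and every measured compound carries the cyano group, so its removal is untested here. The expectation for compound 4 therefore rests only on the value of compound 3 and on the absence of any example of the change. The account expects a moderate rise in the number, with wide uncertainty. Compound 4 is estimated at 400 nM, with a range from 120 nM to 1500 nM. This corresponds to an expected step of a 2.5-fold higher number from compound 3 to compound 4 (0.40 log units; beyond the scatter) in this assay.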

Compound 4, half-maximal inhibitory concentration: <= 1000 nM
Compound 4 gave a limit, no number (the forecaster's own chance of this, stated with the estimate: 5%); the middle value lies beyond the limit too.
By their numbers in this assay, from the lowest: compound 1; then compound 3; then compound 2.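

In this assay compound 4 gives <= 1000 nM, which is a limit and not a number. The step from compound 3 to compound 4 therefore cannot be read. The compounds shown leave open how large a change, and in which direction, bromo in place of cyano on an aromatic carbon brings in this assay.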